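The compounds below may be only part of what the source reports. "The series", "measured", "known", "first", "only" and "open" are said of these compounds alone.

Compound 1 `CC1(C)[C@H]2CC[C@]1(C)N(Cc1cn(-c3ccccc3C#N)nn1)C(=O)C2` gives 240 nM in a functional assay on PANC-1 cells (Homo sapiens) for inhibition, read by MTT assay, with a stated time of 24 h; on this read-out higher numbers stand for weaker inhibition and lower numbers for stronger inhibition.
Compound 2 `CC1(C)[C@H]2CC[C@]1(C)N(Cc1cn(-c3cccc(O)c3)nn1)C(=O)C2` gives 280 nM in this assay.
Compound 3 `CC1(C)[C@H]2CC[C@]1(C)N(Cc1cn(-c3ccc(C#N)cc3)nn1)C(=O)C2` gives 250 nM in this assay.

Compound 3 stands second highest of the three numbers, but its steps to both neighbours, a 1.0-fold higher number from compound 1 to compound 3 (0.02 log units; within the scatter) and a 1.1-fold lower number from compound 2 to compound 3 (0.05 log units; within the scatter), lie within the scatter, so no order among compounds 1, 2 and 3 can be read from these values. All three measured steps, a 1.2-fold higher number from compound 1 to compound 2 (0.07 log units; within the scatter), a 1.0-fold higher number from compound 1 to compound 3 (0.02 log units; within the scatter) and a 1.1-fold lower number from compound 2 to compound 3 (0.05 log units; within the scatter), exchange the aryl group on the aromatic nitrogen while the shared core is kept, and none of them moves the number beyond the scatter.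

Compound 4 `Cc1cccc(-n2cc(CN3C(=O)C[C@@H]4CC[C@@]3(C)C4(C)C)nn2)c1` is the next member: 3-methylphenyl in place of 4-cyanophenyl on an aromatic nitrogen. Within the data shown here, no measured step brings in 3-methylphenyl, so the expectation rests only on the three aryl exchanges already seen, each of which stayed within the scatter. The expected step is therefore a 1.0-fold higher number from compound 3 to compound 4 (0.02 log units; within the scatter), with no direction beyond the scatter. Compound 4 is estimated at 260 nM in this assay, with a range from 130 nM to 520 nM.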

Compound 4, half-maximal inhibitory concentration: 240 nM
For compound 4 the middle estimate is 1.1-fold (0.03 log units) above the measured one, within the range that was stated.
By their numbers in this assay, from the lowest: compounds 1, 4, 3 and 2 (each within the scatter of the next).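

On the aromatic nitrogen of the five-membered aromatic ring, 3-methylphenyl, with 0 hydrogen-bond donors and 0 hydrogen-bond acceptors, stays level with the cyanophenyl groups in this assay (first a 1.0-fold lower number from compound 3 to compound 4 (0.02 log units; within the scatter) and then no change at the digits printed from compound 1 to compound 4 (within the scatter)). Methyl in place of hydroxy on an aromatic carbon also leaves the number within the scatter (a 1.2-fold lower number from compound 2 to compound 4 (0.07 log units; within the scatter)), so among compounds 1 to 4, an aryl group with no hydrogen-bond donor or acceptor matches those that carry one. No available data give a reason for this flat response.

On these data alone, it remains open whether a phenyl group carrying an amine or a carboxylic acid would hold the number at this level. As far as these compounds go, the outcome is equally open for a longer chain in place of the methyl, or for a plain alkyl chain in place of the whole aryl group on the aromatic nitrogen.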